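A few compounds are considered here, and "the series" means these few. Any claim that something is new, unique, unknown or untested is made for them only; others in the source may bear on it.

In a functional assay on HCT-116 cells (Homo sapiens) for antiproliferative activity, read by MTT assay, with a stated time of 72 h (on this read-out lower numbers stand for stronger inhibition and higher numbers for weaker inhibition), compound 1 `O=C(Nc1ccc(Nc2nccc(NC3CCCC3)n2)cc1)Nc1ccc(Cl)c(C(F)(F)F)c1` gives 2510 nM, the lower of the two values in this set that are true numbers. Compound 2 `O=C(Nc1ccc(Nc2nccc(NC3CC3)n2)cc1)Nc1ccc(Cl)c(C(F)(F)F)c1` gives 16400 nM, which is a 6.5-fold higher number from compound 1 to compound 2 (0.82 log units; beyond the scatter). Compound 3 `O=C(Nc1ccc(Nc2nccc(Nc3ccccc3)n2)cc1)Nc1ccc(Cl)c(C(F)(F)F)c1` reaches only a limit of the assay, > 50000 nM. Compound 4 `O=C(Nc1ccc(Nc2nccc(Nc3cccc(Cl)c3)n2)cc1)Nc1ccc(Cl)c(C(F)(F)F)c1` carries 3-chlorophenyl in place of cyclopentyl on a nitrogen on an aromatic ring. For the measured compounds named here, the closest precedent is the phenyl change, an at least 19-fold higher number from compound 1 to compound 3 (1.29 log units; beyond the scatter), so a large rise in the number is expected for compound 4 in this assay. Going by the values given here, no measured compound shows what the chlorine adds. The expected step is a 10-fold higher number from compound 1 to compound 4 (1.00 log units; beyond the scatter). Compound 4 is estimated at 25000 nM, with an expected range from 7000 nM to 50000 nM.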

Compound 4, half-maximal inhibitory concentration: 4820 nM
For compound 4 the middle estimate is 5.2-fold (0.71 log units) above the measured one, outside the stated range (below it).
By their numbers in this assay, from the lowest: compounds 1 and 4 (each within the scatter of the next); then compound 2. At a limit, above all of these: compound 3.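

On a nitrogen on an aromatic ring, an aromatic group can match the cycloalkyl result: 3-chlorophenyl gives a 1.9-fold higher number from compound 1 to compound 4 (0.28 log units; within the scatter), and it also improves on cyclopropyl, with a 3.4-fold lower number from compound 2 to compound 4 (0.53 log units; beyond the scatter). Chloro in place of hydrogen on an aromatic carbon turns the inactive-looking phenyl compound into a measurable one, with an at least 10-fold lower number from compound 3 to compound 4 (1.01 log units; beyond the scatter). Compound 3 stands at a limit, not at a true number: the limit of > 50000 nM in this assay, at which 1 of the 4 values shown sits.

From the compounds shown here alone, whether this gain is specific to chlorine stays open, as a fluoro or methoxy group in its place would be needed to tell. The compounds shown give no cause for the step.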